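Furan-2-yl replacing 4-hydroxy-3-methoxyphenyl on the shared core

The source may hold more compounds than are shown below. What is called first, only, known or untested is meant among the compounds shown, and "the series" means these compounds.

Among the measured compounds shown here, in an ADME assay on Vero cells (Chlorocebus sabaeus) for cytotoxicity, read by MTT assay (a higher number here means a weaker inhibitor, a lower number a stronger inhibitor), compound 1 (`C=CCOc1cc(OC)c(C(=O)/C=C/c2ccccn2)c(OCC=C)c1`) gives 2800 nM as the only number so far. For compound 2 (`C=CCOc1cc(OC)c(C(=O)/C=C/c2ccc(O)c(OC)c2)c(OCC=C)c1`) the entry is "not determined" (no result reported) with no number, so it cannot be ranked. Compound 3 (`C=CCOc1cc(OC)c(C(=O)/C=C/c2ccco2)c(OCC=C)c1`) is still unmeasured. The structural change reads furan-2-yl in place of 4-hydroxy-3-methoxyphenyl on a double-bonded chain carbon bound to a double-bonded chain carbon and touches nothing else. With only the value of compound 1 at 2800 nM as a guide, no step beyond the scatter is expected for this change in this assay and no direction is favoured. Compound 3 is estimated at 3000 nM with an expected range from 1200 nM to 8000 nM as its half-maximal inhibitory concentration.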

Compound 3, half-maximal inhibitory concentration: 191000 nM
Compound 3: the middle estimate sits 64-fold (1.80 log units) below what was measured; the measured number lies above the stated range.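

In this assay, the group on a double-bonded chain carbon bound to a double-bonded chain carbon proves decisive: furan-2-yl in place of pyridin-2-yl gives a 68-fold higher number from compound 1 to compound 3 (1.83 log units; beyond the scatter). Steps involving compound 2 cannot be read, so the change from 4-hydroxy-3-methoxyphenyl to furan-2-yl remains unquantified. Nothing available accounts for the size of this step. Open, as far as these compounds go, is whether thiophen-2-yl or unsubstituted phenyl at this place would read closer to compound 1 or to compound 3. Also open, from the compounds shown here alone, is whether an amine on the ring would shift the number.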